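Removing the Chloro: Solubility Expectation for Compound 4

The compounds below may be only part of what the source reports. "The series", "measured", "known", "first", "only" and "open" are said of these compounds alone.

Measured compounds:
- compound 1, `CCC(=O)c1cc(-c2ccccc2)n(-c2ccc(S(N)(=O)=O)cc2)c1C`, 14100 nM
- compound 2, `CCC(=O)c1cc(-c2ccccc2Cl)n(-c2ccc(S(N)(=O)=O)cc2)c1C`, 38200 nM
- compound 3, `CCC(=O)c1cc(-c2ccc(S(N)(=O)=O)cc2)n(-c2ccccc2Cl)n1`, 4700 nM

In a physicochemical assay for solubility, read by HPLC, in phosphate buffer, measured as kinetic solubility, at pH 7.4 (on this read-out higher numbers stand for higher solubility and lower numbers for lower solubility), compound 2 gives 38200 nM, while compound 1 gives 14100 nM. The change between them is hydrogen in place of chloro on an aromatic carbon, and it made a 2.7-fold lower number from compound 2 to compound 1 (0.43 log units; beyond the scatter). Compound 3, which gives 4700 nM in this assay, has a different core; how its core differs from that of compound 2 is not broken down here. Compound 4, `CCC(=O)c1cc(-c2ccc(S(N)(=O)=O)cc2)n(-c2ccccc2)n1`, is not yet measured. It differs from compound 3 by hydrogen in place of chloro on an aromatic carbon, the same change as from compound 2 to compound 1. Because the earlier step was a 2.7-fold lower number from compound 2 to compound 1 (0.43 log units; beyond the scatter), compound 4 is expected to show a similar drop, a 2.6-fold lower number from compound 3 to compound 4 (0.42 log units; beyond the scatter). The estimate for compound 4 is 1800 nM, between 800 nM and 4000 nM.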

Compound 4, solubility: 47200 nM
For compound 4 the middle estimate is 26-fold (1.42 log units) below the measured one, and the stated range ends below it.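

In this assay putting hydrogen in place of chloro gave a 10-fold higher number from compound 3 to compound 4 (1.00 log units; beyond the scatter) on one core, but the same change on the other core gave a 2.7-fold lower number from compound 2 to compound 1 (0.43 log units; beyond the scatter) in the opposite direction. In these two pairs, then, the change did not carry from one core to the other, not even in its sign, although two pairs cannot show how it would behave on further cores. Nothing given here bears on why the two cores part ways.

The compounds shown hold only chloro or hydrogen at this place on the ring. As far as these compounds go, whether a fluoro or a methoxy group there would also split the two cores remains open, as does the outcome on any third core.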